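The compounds below may be only part of what the source reports. "The series", "measured", "known", "first", "only" and "open" are said of these compounds alone.

Measured compounds in this series:
Compound 1, `COc1cc(OC)c2c(=O)cc(C(=O)Nc3ccc(N4CCN(C)CC4)cc3)[nH]c2c1`. In a functional assay on SUP-B15 cells (Homo sapiens) for antiproliferative activity, with a stated time of 72 h (on this read-out higher numbers stand for an effect only at larger amounts of compound and lower numbers for an effect already at smaller amounts), compound 1 gives > 19800 nM, which is a limit of the assay.
Compound 2, `COc1cc(OC)c2c(=O)cc(C(=O)Nc3ccc(-n4cccc4)cc3)[nH]c2c1`. In this assay compound 2 gives > 77000 nM, also a limit of the assay.

The step from compound 1 to compound 2, a step that the two limits leave unreadable from compound 1 to compound 2, cannot be read, since both ends sit at a limit, as shown by the limit of > 19800 nM in this assay, at which 1 of the 2 values shown sits, and (the limit of > 77000 nM in this assay, at which 1 of the 2 values shown sits). Compound 2 therefore stands only at a limit, with no number behind it.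

Compound 3, `COc1cc(OC)c2c(=O)cc(C(=O)Nc3ccc(S(=O)(=O)c4ccccc4)cc3)[nH]c2c1`, differs from compound 2 by phenylsulfonyl in place of 1H-pyrrol-1-yl on an aromatic carbon. Going by the values given here, the single measured step bears on this change only in that neither of its ends reached a readable number; no direction or size can be drawn from it. For compound 3 the expectation is a step of an at least 1.5-fold lower number from compound 2 to compound 3 (0.18 log units; that floor lies within the scatter) in this assay, not separable from the scatter, with a further limit the most likely outcome. The estimate for compound 3 in this assay is 50000 nM, between 15000 nM and 150000 nM.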

Compound 3, half-maximal effective concentration: > 70600 nM
Compound 3: only a limit was reported; the forecaster's own chance of this, stated with the estimate: 80%; at least 1.4-fold (0.14 log units) between middle value and limit.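

In this assay, going by these compounds alone, compound 1, compound 2 and compound 3 all stand only at limits of the assay, so no step among them can be read. The compounds shown leave open how 4-methylpiperazin-1-yl, 1H-pyrrol-1-yl and phenylsulfonyl rank against one another on this aromatic carbon.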